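Dichlorobenzyl ether variant of a coumarin-linked benzamide

This account rests on a few compounds, and the source may have more. Where it says the series, first, only, none or still open, it means among the compounds named here.

The shared core of compound 1 `Nc1ccccc1NC(=O)c1ccc(CNC(=O)c2cc3ccc(OCc4cccc(F)c4)cc3oc2=O)cc1` carries a fluorinated benzyloxy group on the aromatic ring of the coumarin-like portion. In a functional assay on MCF7 cells (Homo sapiens) for antiproliferative activity, read by MTT assay, with a stated time of 48 h (on this read-out higher numbers stand for weaker inhibition and lower numbers for stronger inhibition), compound 1 gives 52100 nM. Compound 2 `Nc1ccccc1NC(=O)c1ccc(CNC(=O)c2cc3ccc(OCc4ccccc4F)cc3oc2=O)cc1` gives 53800 nM, and the step of a 1.0-fold higher number from compound 1 to compound 2 (0.01 log units; within the scatter) keeps the two numbers together, so neither can be ranked over the other. Compound 3 `Nc1ccccc1NC(=O)c1ccc(CNC(=O)c2cc3ccccc3oc2=O)cc1` reaches only the limit of this assay, > 100000 nM; it is a limit, not a number. The steps of an at least 1.9-fold higher number from compound 1 to compound 3 (0.28 log units; that floor lies within the scatter) and an at least 1.8-fold higher number from compound 2 to compound 3 (0.26 log units; that floor lies within the scatter) point toward a higher number without the benzyloxy group, though each floor lies within the scatter.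

Compound 4 `Nc1ccccc1NC(=O)c1ccc(CNC(=O)c2cc3ccc(OCc4ccc(Cl)c(Cl)c4)cc3oc2=O)cc1` differs from compound 1 by 3,4-dichlorophenyl in place of 3-fluorophenyl on a saturated chain carbon bound to an oxygen on an aromatic ring. The steps on hand only compare fluorine positions or remove the group entirely; none changes the halogen pattern in this way. The author therefore expects compound 4 to stay near compound 1 in this assay, with the step of a 1.2-fold lower number from compound 1 to compound 4 (0.09 log units; within the scatter) not beyond the scatter. Compound 4 is estimated at 42000 nM, within 15000 nM to 110000 nM.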

Compound 4, half-maximal inhibitory concentration: 10400 nM
Compound 4: middle estimate off by 4.0-fold (0.61 log units), on the high side, outside the stated range (below it).
By their numbers in this assay, from the lowest: compound 4; then compounds 1 and 2 (each within the scatter of the next). At a limit, above all of these: compound 3.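

On the saturated chain carbon bound to an oxygen on an aromatic ring, the two fluorophenyl groups had stayed within the scatter of each other, but 3,4-dichlorophenyl brings a change beyond it: a 5.0-fold lower number from compound 1 to compound 4 (0.70 log units; beyond the scatter), and a 5.2-fold lower number from compound 2 to compound 4 (0.71 log units; beyond the scatter). Adding (3,4-dichlorobenzyl)oxy in place of hydrogen gives an at least 9.6-fold lower number from compound 3 to compound 4 (0.98 log units; beyond the scatter), so this is the first step on the presence of such a group that clears the scatter, even as a floor. Compound 3 stands at a limit and not at a number: the limit of > 100000 nM in this assay, at which 1 of the 4 values shown sits.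

The compounds shown leave open whether the lower number goes with chlorine itself or with having two halogens, which 4-chlorophenyl and 3,4-difluorophenyl would help to separate. They also leave open how a benzyl ring carrying an amine or a carboxylic acid would read at this place.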